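Urea-linked series: removing the chloro substituent from compound 3

This account rests on a few compounds, and the source may have more. Where it says the series, first, only, none or still open, it means among the compounds named here.

Measured so far in a functional assay on HUVEC cells (Homo sapiens) for antiproliferative activity, read by MTT assay, with a stated time of 48 h; a higher number here means a weaker inhibitor, a lower number a stronger inhibitor:

compound 1 `O=C(Nc1ccccc1)Nc1nnc(Sc2ncnc3scc(-c4ccncc4)c23)s1` gives 19300 nM
compound 2 `Cc1cccc(NC(=O)Nc2nnc(Sc3ncnc4scc(-c5ccncc5)c34)s2)c1` gives 12200 nM
compound 3 `Cc1ccc(NC(=O)Nc2nnc(Sc3ncnc4scc(-c5ccncc5)c34)s2)cc1Cl` gives 23200 nM

Compound 3 holds the highest number of the three, yet every comparison to it stays inside the scatter: a 1.2-fold higher number from compound 1 to compound 3 (0.08 log units; within the scatter) and a 1.9-fold higher number from compound 2 to compound 3 (0.28 log units; within the scatter). On these numbers compound 3 cannot be told apart from compound 1 or compound 2.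

Compound 4 `Cc1ccc(NC(=O)Nc2nnc(Sc3ncnc4scc(-c5ccncc5)c34)s2)cc1` has not yet been measured in this assay. Relative to compound 3 the change is hydrogen in place of chloro on an aromatic carbon. The chloro leaves an aromatic carbon ortho to a methyl group and meta to a large group; one heavy atom goes, nothing heavy comes in.

Among the measured compounds shown here, two measured steps bear on it. The step of a 1.2-fold higher number from compound 1 to compound 3 (0.08 log units; within the scatter) adds chloro and methyl together onto the phenyl ring and stays inside the scatter. The step of a 1.6-fold lower number from compound 1 to compound 2 (0.20 log units; within the scatter) adds a methyl alone and also stays inside the scatter. Neither substituent has so far shifted the read-out beyond noise, so taking the chloro away again is not expected to do so either. The expected step in this assay is therefore a 1.5-fold lower number from compound 3 to compound 4 (0.16 log units; within the scatter), a change within the scatter in either direction.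

For compound 4 the estimated value in this assay is 16000 nM, with a range from 7000 nM to 35000 nM.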

Compound 4, half-maximal inhibitory concentration: 19300 nM
Compound 4: the middle estimate sits 1.2-fold (0.08 log units) below what was measured, and the stated range covers the measured number.
By their numbers in this assay, from the lowest: compounds 2, 1, 4 and 3 (each within the scatter of the next).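

In this assay, the chloro can now be read on its own rather than together with the methyl: hydrogen in place of chloro on the aromatic carbon ortho to a methyl group gives a 1.2-fold lower number from compound 3 to compound 4 (0.08 log units; within the scatter), so this change does not separate the two compounds. Among the compounds shown here, the methyl is also isolated for the first time on the 4-methylphenyl urea, with no change at the digits printed from compound 1 to compound 4 (within the scatter), while 4-methylphenyl in place of 3-methylphenyl gives a 1.6-fold higher number from compound 2 to compound 4 (0.20 log units; within the scatter), so neither adding this methyl nor the difference between these two methylphenyl groups is resolved by this assay. Across compounds 1 to 4, phenyl, 3-methylphenyl, 4-methylphenyl and 3-chloro-4-methylphenyl therefore all remain indistinguishable, and no compound among these four goes against that reading.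

Still open is whether a different kind of group on this ring, such as an amine, a carboxylic acid or a methoxy group, would shift the read-out beyond the scatter, since chloro and methyl are the only substituents shown here. No supporting data bear on why these steps stay so small.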